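The source may hold more compounds than are shown below. What is called first, only, known or untested is meant among the compounds shown, and "the series" means these compounds.

Measured so far in a physicochemical assay for lipophilicity; on this read-out lower numbers stand for lower lipophilicity and higher numbers for higher lipophilicity:
- compound 1 `COC(C)(C)CCCC(C)C/C=C/C(C)=C/C(=O)OCCC(C)C`: 7.03
- compound 2 `CCNC(=O)OC(C)(C)CCCC(C)C/C=C/C(C)=C/C(=O)OCC`: 5.65
- compound 3 `C=C(C)CCCC(C)C/C=C/C(C)=C/C(=O)OCC`: 6.19

Compound 1 stands highest of the three numbers in this assay. The nearest is compound 3, whose value lies lower by a gap beyond the scatter; compound 2 sits lower still, also beyond the scatter. No pair among these three differs in one place only, so nothing more is read from them than the ordering of the values.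

The step now followed goes from compound 1 to compound 4 `COC(C)(C)CCCC(C)C/C=C/C(C)=C/C(N)=O`. The change is amino in place of isopentyloxy on a carbonyl carbon. Nothing measured here isolates this kind of exchange, so the expectation rests on the structural change alone: a six-heavy-atom isopentyloxy group leaves and a single-heavy-atom amino group with one hydrogen-bond donor enters on the carbonyl carbon.

The step is expected to be large and downward, a number 3.63 log units lower from compound 1 to compound 4 (beyond the scatter), well beyond the scatter. Compound 4 is therefore estimated at 3.4 in this assay, within the range 2.6 to 4.2.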

Compound 4, partition coefficient: 3.52
The estimate for compound 4 lay 0.12 log units below the measured number; measured number inside the range.
By their numbers in this assay, from the lowest: compound 4; then compound 2; then compound 3; then compound 1.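

In this assay, for the compounds shown here, the exchange of isopentyloxy for amino on a carbonyl carbon provides the first step that changes one place only: a number 3.51 log units lower from compound 1 to compound 4 (beyond the scatter), a large step beyond the scatter. Going by these compounds alone, the read-out is therefore strongly sensitive to this exchange on the carbonyl carbon, which the earlier compounds, differing in more than one place, could not show. The change replaces a group of 6 heavy atoms with no hydrogen-bond donor by a group of 1 heavy atom with 1 hydrogen-bond donor, and nothing available explains the size of the step or divides it between these differences.

A methylamino or dimethylamino group, or a carboxylic acid, on the same carbonyl carbon would show how much of the step depends on the amino group itself. Also open, from the compounds shown here alone, is whether the exchange keeps this size when the rest of the molecule differs from compound 1.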